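Phenyl extension of the benzyl amide: expectation for compound 3

This account rests on a few compounds, and the source may have more. Where it says the series, first, only, none or still open, it means among the compounds named here.

Two analogues of the shared core have been measured, differing only in the substituent on one amide nitrogen. Compound 1 `O=C(NC1CCCCC1)c1nc[nH]c1C(=O)Nc1ccc(Cl)c(Cl)c1` carries a cyclohexyl there and in a functional assay on HL-60 cells (Homo sapiens), with a stated time of 2 days (on this read-out higher numbers stand for weaker inhibition and lower numbers for stronger inhibition), compound 1 gives 33100 nM. Within the data shown here, compound 2 `O=C(NCc1ccccc1)c1nc[nH]c1C(=O)Nc1ccc(Cl)c(Cl)c1` carries a benzyl; in this assay compound 2 gives 11500 nM, the lowest of the two numbers so far. Among the measured compounds shown here, the single step available is a 2.9-fold lower number from compound 1 to compound 2 (0.46 log units; beyond the scatter). Compound 3 `O=C(NCc1ccc(-c2ccccc2)cc1)c1nc[nH]c1C(=O)Nc1ccc(Cl)c(Cl)c1` differs from compound 2 by phenyl in place of hydrogen on an aromatic carbon. For the measured compounds named here, no measured step addresses adding a phenyl to the benzyl; the one step measured only shows that an aromatic substituent was favoured over a saturated one, so any carry-over is indirect. A modest further lowering, or none beyond the scatter, is expected. Compound 3 is expected to give 6000 nM, within a range of 1500 nM to 25000 nM. The expected step is a 1.9-fold lower number from compound 2 to compound 3 (0.28 log units; within the scatter).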

Compound 3, half-maximal inhibitory concentration: 7000 nM
For compound 3 the middle estimate is 1.2-fold (0.07 log units) below the measured one, within the range that was stated.
By their numbers in this assay, from the lowest: compounds 3 and 2 (each within the scatter of the next); then compound 1.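

In this assay, phenyl in place of hydrogen on an aromatic carbon, para to a large group, gives a 1.6-fold lower number from compound 2 to compound 3 (0.22 log units; within the scatter). Among these compounds, the earlier step concerned only the exchange of cyclohexyl for benzyl on the amide nitrogen, whereas this one is a first reading on the aromatic ring of the benzyl: an added six-membered aromatic ring of 6 heavy atoms is tolerated here, with no shift beyond the scatter. Nothing available explains this tolerance.

Going by these compounds, whether an amine, a carboxylic acid or a methoxy group at this same carbon would move the number beyond the scatter remains open. Also open, on these data alone, is how a longer chain, such as phenethyl in place of benzyl on the amide nitrogen, would read out.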